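Tetrazole-bearing chain variations in a leukotriene antagonist series

A few compounds are considered here, and "the series" means these few. Any claim that something is new, unique, unknown or untested is made for them only; others in the source may bear on it.

Measured so far:
compound 1 `CCCc1c(COc2ccc(C(=O)Cc3nnn[nH]3)cc2)ccc(C(C)=O)c1O`: 7.71
compound 2 `CCCc1c(COc2ccc(C(=O)CC(C)(C)Cc3nnn[nH]3)cc2)ccc(C(C)=O)c1O`: 7.86

Working notes. Among the compounds with values here, in a functional assay on ileum (Cavia porcellus) with cysteinyl leukotriene receptor (Homo sapiens) as the target (on this read-out lower numbers stand for lower potency and higher numbers for higher potency (the scale is a negative logarithm)), compound 2 gives the higher of the two numbers on hand, and compound 1 gives 7.71; the only measured step, a number 0.15 log units higher from compound 1 to compound 2 (within the scatter), lies within the scatter, so the two compounds are not separated by these data. Compound 3 `CCCc1c(COc2ccc(C(=O)CCCCc3nnn[nH]3)cc2)ccc(C(C)=O)c1O` is the next candidate. Relative to compound 2 its change is 3-(1H-tetrazol-5-yl)propyl in place of 1-((1H-tetrazol-5-yl)methyl)-1-methylethyl on a saturated chain carbon bound to a carbonyl carbon. Within the data shown here, the one step that bears on this is the step from compound 1 to compound 2, in which the tetrazole was moved out along a branched saturated chain without a change beyond the scatter. Compound 3 keeps a tetrazole at the end of a saturated chain of comparable length and removes the branching; nothing measured here speaks for a step beyond the scatter in this assay in either direction. The expected step is therefore a number 0.06 log units lower from compound 2 to compound 3 (within the scatter). Compound 3 is estimated at 7.8, with a range from 7.3 to 8.3.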

Compound 3, negative logarithm of the antagonist equilibrium constant: 7.28
For compound 3 the middle estimate is 0.52 log units above the measured one; the whole stated range lies above it.
By their numbers in this assay, from the lowest: compound 3; then compounds 1 and 2 (each within the scatter of the next).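

At the saturated chain carbon bound to a carbonyl carbon, the chain carrying the tetrazole now proves able to move the number in this assay: 3-(1H-tetrazol-5-yl)propyl in place of 1-((1H-tetrazol-5-yl)methyl)-1-methylethyl gives a clear loss (a number 0.58 log units lower from compound 2 to compound 3 (beyond the scatter)), and the same group in place of 1H-tetrazol-5-yl also gives a loss (a number 0.43 log units lower from compound 1 to compound 3 (beyond the scatter)). Compound 1 and compound 2 remain within the scatter of each other, so the short chain and the branched chain cannot be separated, whereas the unbranched chain stands apart from both, and a longer tether therefore does not carry a uniform outcome across these three compounds. Nothing available here accounts for the lower number of compound 3.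

Three compounds cannot show whether the loss follows from the absence of the branching or from the exact length of the chain, and a single methyl branch on the butyl-type chain would be needed to separate the two. Going by these compounds, it also stays open whether a longer unbranched chain, or a carboxylic acid in place of the tetrazole at the chain end, would follow compound 3 or stay with compound 1 and compound 2.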